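Estimating a benzyloxycarbonyl swap on compound 2

The compounds below may be only part of what the source reports. "The series", "measured", "known", "first", "only" and "open" are said of these compounds alone.

Measured in a functional assay on A549 cells (Homo sapiens) for antiproliferative activity, read by MTT assay, with a stated time of 48 h; a lower number here means a stronger inhibitor, a higher number a weaker inhibitor:
- compound 1 `Clc1ccc2[nH]c(-c3cn(-c4ccccc4)nc3-c3ccccc3)nc2c1` gives 2370 nM
- compound 2 `Cc1ccc2[nH]c(-c3cn(-c4ccccc4)nc3-c3ccccc3)nc2c1` gives 3610 nM
- compound 3 `Cc1cc2nc(-c3cn(-c4ccccc4)nc3-c3ccccc3)[nH]c2cc1C` gives 14500 nM

Compound 2 at 3610 nM lies within the usual scatter of compound 1, while compound 3 has a clearly higher number. The unmeasured compound 4 `O=C(OCc1ccccc1)c1ccc2[nH]c(-c3cn(-c4ccccc4)nc3-c3ccccc3)nc2c1` keeps the shared core and carries benzyloxycarbonyl in place of methyl on an aromatic carbon.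

Two measured steps offer guidance. Exchanging one small group for another gave a 1.5-fold higher number from compound 1 to compound 2 (0.18 log units; within the scatter). Adding one methyl gave a 4.0-fold higher number from compound 2 to compound 3 (0.60 log units; beyond the scatter). Neither step introduces anything as large as benzyloxycarbonyl, so together they give only weak guidance and point to no clear direction. The expected result in this assay is therefore no step beyond the scatter, with real uncertainty either way. The estimated step is a 1.1-fold higher number from compound 2 to compound 4 (0.04 log units; within the scatter). For compound 4 the expected value is 4000 nM, within an estimated range of 1000 nM to 16000 nM.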

Compound 4, half-maximal inhibitory concentration: 19300 nM
The estimate for compound 4 lay 4.8-fold (0.68 log units) below the measured number, outside the stated range (above it).
By their numbers in this assay, from the lowest: compounds 1 and 2 (each within the scatter of the next); then compounds 3 and 4 (each within the scatter of the next).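

In this assay, going by these compounds alone, chloro and methyl at this position had stayed within the scatter of each other, so the earlier compounds gave no sign that the position was sensitive to change. Benzyloxycarbonyl now shows that it is: the exchange for methyl gives a 5.3-fold higher number from compound 2 to compound 4 (0.73 log units; beyond the scatter) and the exchange for chloro gives an 8.1-fold higher number from compound 1 to compound 4 (0.91 log units; beyond the scatter) as well, both beyond the scatter. No measurement shown here explains this loss of activity.

The new group differs from methyl in several ways at once, including its size, its added aromatic ring and its hydrogen-bond acceptors, and these compounds cannot separate those features. On these data alone, it remains open whether a carboxylic acid or a smaller methoxycarbonyl at the same place would give a number closer to compound 2 or to compound 4.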